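A few compounds are considered here, and "the series" means these few. Any claim that something is new, unique, unknown or untested is made for them only; others in the source may bear on it.

Working notes on the series, following the change from compound 2 to compound 3. Compound 2 (`C/C(=N\NC(N)=S)c1ccc2c(c1)nc(-c1ccc(C(F)(F)F)cc1)n2C1CCCCC1`) gives > 100000 nM in an ADME assay on BHK-21 cells (Mesocricetus auratus) for cytotoxicity, read by MTT assay (a lower number here means that less compound is tolerated, a higher number that more compound is tolerated), and this reading is a limit of the assay, not a number. Going by the values given here, compound 1 (`CC(=O)c1ccc2c(c1)nc(-c1ccoc1)n2C1CCCCC1`), the only other measured compound, gives 77000 nM in this assay, and it also carries a furan-3-yl group.

Compound 3 (`C/C(=N\NC(N)=S)c1ccc2c(c1)nc(-c1ccoc1)n2C1CCCCC1`) differs from compound 2 in one place: furan-3-yl in place of 4-(trifluoromethyl)phenyl on an aromatic carbon of a five-membered aromatic ring with 2 nitrogen (furan-3-yl in place of 4-(trifluoromethyl)phenyl on an aromatic carbon). Among the compounds with values here, no measured pair isolates this change, so any expectation rests on very little. The closest guide is compound 1 at 77000 nM, which gives a numerical reading with the incoming group in place. On that basis, a small shift toward less compound tolerated is expected, and a reading at the limit of the assay remains quite possible. The expected step of an at least 1.2-fold lower number from compound 2 to compound 3 (0.09 log units; that floor lies within the scatter) is small. For compound 3 the estimated value is 80000 nM, with an expected range of 30000 nM to 100000 nM.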

Compound 3, half-maximal cytotoxic concentration: > 100000 nM
Compound 3 ended at the assay's limit; the forecaster's own chance of this, stated with the estimate: 40%; at least 1.2-fold (0.09 log units) between middle value and limit.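

In this assay, the step from 4-(trifluoromethyl)phenyl to furan-3-yl, on the aromatic carbon between two ring nitrogen atoms, cannot be read: compound 2 and compound 3 both give limits of the assay, not numbers, so the change has no measurable size here and only shows that the smaller furan-3-yl group does not bring the reading below the limit. The new information comes from the other one-place pair, which keeps furan-3-yl and swaps the group of 3 heavy atoms for the group of 7 heavy atoms on an aromatic carbon: it gives an at least 1.2-fold higher number from compound 1 to compound 3 (0.11 log units; that floor lies within the scatter), so this pair does not separate the two groups beyond the usual scatter. The series so far gathers at a single reading: the limit of > 100000 nM in this assay, at which 2 of the 3 values shown sit.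

Open, as far as these compounds go, is whether a different group at this position, such as an amine or a carboxylic acid, would give a numerical reading in this assay. Also open, from the compounds shown here alone, is how the group of 3 heavy atoms behaves with 4-(trifluoromethyl)phenyl in place of furan-3-yl on the shared core.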